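Methyl for methoxy on the aryl carbamate of a selenocyanate

The compounds below may be only part of what the source reports. "The series", "measured", "known", "first", "only" and "open" are said of these compounds alone.

Measured so far:
Compound 1 `COc1ccc(OC(=O)Nc2ccc([Se]C#N)cc2)cc1`: 25200 nM
Compound 2 `CCCCCCOC(=O)Nc1ccc([Se][Se]c2ccc(NC(=O)OCCCCCC)cc2)cc1`: 10 nM

In an ADME assay on BEAS-2B cells (Homo sapiens) for cytotoxicity, read by MTT assay, with a stated time of 72 h (a lower number here means a stronger inhibitor of growth, a higher number a weaker inhibitor of growth), compound 1 gives 25200 nM, the higher of the two numbers. Compound 2, a diselenide of a different build, gives 10 nM, a far lower number, well beyond the scatter. Compound 3 `Cc1ccc(OC(=O)Nc2ccc([Se]C#N)cc2)cc1` differs from compound 1 by a single small exchange: methyl in place of methoxy on an aromatic carbon. Among the compounds with values here, no measured pair shows what such an exchange does here, so no step beyond the scatter is expected in either direction in this assay. For compound 3 the estimate is therefore 25000 nM, within 10000 nM to 60000 nM, a step of a 1.0-fold lower number from compound 1 to compound 3 (0.00 log units; within the scatter) expected to stay inside the scatter.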

Compound 3, concentration for 50% growth inhibition: 5600 nM
The estimate for compound 3 lay 4.5-fold (0.65 log units) above the measured number; measured number outside the range, below it.
By their numbers in this assay, from the lowest: compound 2; then compound 3; then compound 1.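

Putting methyl in place of methoxy on the aromatic carbon para to a large group gives a 4.5-fold lower number from compound 1 to compound 3 (0.65 log units; beyond the scatter) in this assay. Within the data shown here, the step is modest, but it shows that this position is not indifferent to a small exchange on the selenocyanate core of compound 1, something the earlier compounds, which differ in more than one place, could not show.

Going by these compounds, whether an amine or a longer alkyl chain at this carbon would move the number further remains open. No measurement shown explains the step.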